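A few compounds are considered here, and "the series" means these few. Any claim that something is new, unique, unknown or untested is made for them only; others in the source may bear on it.

Measured compounds:
compound 1 `Cc1ccc(-c2cn(C/C=C3\OC(=O)C(OCc4ccccc4)=C3OCc3ccccc3)nn2)cc1` – > 100000 nM
compound 2 `COC1=C(OC)C(O)(CCn2cc(-c3ccc(C(C)(C)C)cc3)nn2)NC1=O` – 11300 nM

The account follows the step from compound 1 to compound 3. In a functional assay on MDA-MB-231 cells (Homo sapiens) for antiproliferative activity, read by MTT assay, with a stated time of 24 h (a higher number here means a weaker inhibitor, a lower number a stronger inhibitor), compound 1 gives > 100000 nM, which is a limit of the assay and not a number. Its standing on the numbers shown is therefore set by the limit of > 100000 nM in this assay, at which 1 of the 2 values shown sits: compound 1 is the one of the two measured compounds that sits at this limit. Within the data shown here, compound 2, built on a different core, gives 11300 nM in this assay and is the only measured compound with a numerical value.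

Compound 3 `O=C1O/C(=C\Cn2cc(-c3ccccn3)nn2)C(OCc2ccccc2)=C1OCc1ccccc1` is not yet measured. It differs from compound 1 in one place: pyridin-2-yl in place of 4-methylphenyl on an aromatic carbon. Among the measured compounds shown here, no step between measured compounds is known that would set the size of such a change, so the expectation rests only on where compound 1 stands. Compound 3 is expected to stay near the limit in this assay, with an estimate of 100000 nM and a range from 30000 nM to 300000 nM. The estimated step of a number no higher from compound 1 to compound 3 (the limit leaves the size open) is expected to be none beyond the scatter, in either direction.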

Compound 3, half-maximal inhibitory concentration: > 100000 nM
Compound 3: a limit, no number; the forecaster's own chance of this, stated with the estimate: 70%; the middle value sits exactly at the limit.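

In this assay compound 3 gives > 100000 nM, which is a limit of the assay and not a number. Compound 1 also stands at a limit, so no step between compound 1 and compound 3 can be read: the limit of > 100000 nM in this assay, at which 2 of the 3 values shown sit.

The compounds shown leave open what size of effect, if any, pyridin-2-yl in place of 4-methylphenyl has in this assay.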